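A few compounds are considered here, and "the series" means these few. Any claim that something is new, unique, unknown or untested is made for them only; others in the source may bear on it.

Compound 1 `CCCCCCCCCCCCCCc1nc(N2CCC2)nc(OC2CCC2)c1O`: 94%
Compound 2 `CCCCCCCCCCCCCCc1nc(OC2CCC2)nc(N2CCC2)c1O`: 54%
Compound 3 `CCCCCCCCCCCCCCc1nc(OC2CCC2)nc(OC2CCC2)c1O`: 94%

In a functional assay on cells (Lymphocyte, Homo sapiens), read by a luciferase reporter and ATP content, with a stated time of 48 h, tested at 20 uM (on this read-out higher numbers stand for a weaker effect at the one concentration tested and lower numbers for a stronger effect), compound 2 gives the lowest number of the three, so it shows the strongest effect; compound 1 and compound 3 both sit well above it. Compound 4 `CCCCCCCCCCCCCCc1nc(N2CCC2)nc(N2CCC2)c1O` differs from compound 2 by azetidin-1-yl in place of cyclobutyloxy on an aromatic carbon. For the measured compounds named here, two measured steps concern the same pair of groups in the opposite direction: no change at the digits printed from compound 1 to compound 3 (within the scatter), at the carbon between two ring nitrogen atoms, the place changed here, and a number 40 percentage points higher from compound 2 to compound 3 (beyond the scatter), at a different carbon. Since the change at the carbon between the two ring nitrogen atoms moved nothing, no step beyond the scatter is expected, no change at the digits printed from compound 2 to compound 4 (within the scatter). Compound 4 is therefore estimated at 54%, within 35% to 75%.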

Compound 4, a percentage reported as activity, at one concentration (the size of the read-out at that concentration, not a potency): 1%
Beside the measured number, compound 4's estimate is 53 percentage points above it; the whole stated range lies above it.
By their numbers in this assay, from the lowest: compound 4; then compound 2; then compounds 1 and 3 (each within the scatter of the next).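

In this assay the carbon between two ring nitrogen atoms turns out to matter: azetidin-1-yl in place of cyclobutyloxy there gives a number 53 percentage points lower from compound 2 to compound 4 (beyond the scatter) and so a stronger effect. What this swap does at that carbon depends on the rest of the molecule: the same change on two cores in this assay, no change at the digits printed (within the scatter) from compound 1 to compound 3 and a number 53 percentage points higher (beyond the scatter) from compound 4 to compound 2, 53 percentage points apart, beyond the scatter of two such steps. At the other carbon, the same swap gives a number 93 percentage points lower from compound 1 to compound 4 (beyond the scatter) and also depends on its partner group: the same change on two cores in this assay, a number 40 percentage points higher (beyond the scatter) from compound 2 to compound 3 and a number 93 percentage points higher (beyond the scatter) from compound 4 to compound 1, 53 percentage points apart, beyond the scatter of two such steps. From the compounds shown here alone, whether an open-chain amine such as dimethylamino would act like azetidin-1-yl at either carbon remains open.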